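Bridged Ring Gains an Oxygen: Expecting Compound 4

The compounds below may be only part of what the source reports. "The series", "measured", "known", "first", "only" and "open" are said of these compounds alone.

Measured so far:
Compound 1, `COc1ncccc1C(=O)NCCC1CCN(S(=O)(=O)NC(=O)NC2CCCCC2)CC1`: 33%
Compound 2, `O=C(NC[C@@H]1C[C@@H]2CC[C@@H]1O2)NS(=O)(=O)N1CCC(CCNC(=O)c2cccc3c2OCCO3)CC1`: 15%
Compound 3, `COc1ncccc1C(=O)NCCC1CCN(S(=O)(=O)NC(=O)NC[C@H]2C[C@@H]3C=C[C@@H]2C3)CC1`: 20%

All three were tested in a functional assay on the whole organism (blood) with Rattus norvegicus as the target, with stated times of 24 h and 1 h, at a dose of 5 mg/kg by the intraperitoneal route; a higher number here means a stronger effect of the compound at the dose given, a lower number a weaker effect. Compound 3 holds the second highest of the three numbers. Its nearest neighbour is compound 2, whose value lies within the usual scatter of compound 3, so no order between those two can be read. Compound 1 stands clearly higher: a number 13 percentage points lower from compound 1 to compound 3 (beyond the scatter).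

Compound 4, `COc1ncccc1C(=O)NCCC1CCN(S(=O)(=O)NC(=O)NC[C@@H]2C[C@@H]3CC[C@@H]2O3)CC1`, has not yet been measured. It differs from compound 3 in one place:

a group of 7 heavy atoms (6 carbon, 1 oxygen; 2 five-membered non-aromatic rings with 1 hetero atom each) in place of a group of 7 heavy atoms (7 carbon; 2 five-membered non-aromatic rings of carbon only), on a saturated chain carbon bound to an amide-type nitrogen

Among the measured compounds shown here, no measured step matches this exact change. For the measured compounds named here, the one recorded step, a number 13 percentage points lower from compound 1 to compound 3 (beyond the scatter), concerns a different exchange on the amide-type nitrogen and only shows that this end of the shared core can move the number by a modest amount. Compound 2 carries the same entering group as compound 4, though with a different amide elsewhere, and compound 2 gives 15%, close to compound 3. The step to compound 4 is therefore expected to stay within the scatter: a number 2 percentage points lower from compound 3 to compound 4 (within the scatter). Compound 4 is estimated at 18%, with a range from 8% to 30%.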

Compound 4, a percentage reported as activity, at one dose (the size of the read-out at that dose, not a potency): 34%
Compound 4: middle estimate off by 16 percentage points, on the low side; measured number above the stated range.
By their numbers in this assay, from the lowest: compounds 2 and 3 (each within the scatter of the next); then compounds 1 and 4 (each within the scatter of the next).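

In this assay, replacing the bridged carbon group with its double bond by the bridged group carrying one oxygen, on a saturated chain carbon bound to an amide-type nitrogen, gives a number 14 percentage points higher from compound 3 to compound 4 (beyond the scatter) and shows that this position responds to a change that keeps the count of heavy atoms the same. Compound 2 had suggested that the oxygen-bearing group goes with a low number, but 2-methoxypyridin-3-yl in place of 2,3-dihydro-1,4-benzodioxin-5-yl on a carbonyl carbon gives a number 19 percentage points higher from compound 2 to compound 4 (beyond the scatter) with that group held constant, so the effect of this group cannot be judged apart from the group on the carbonyl carbon. The step of a number 1 percentage points higher from compound 1 to compound 4 (within the scatter) means that no order can be read between the oxygen-bearing bridged group and the six-membered carbon ring it replaces on the amide-type nitrogen.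

The compounds shown leave open whether a bridging amine nitrogen in place of the oxygen, or an unbridged tetrahydrofuran ring, would give a number like that of compound 4. No measurement offered here explains the result.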